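This account rests on a few compounds, and the source may have more. Where it says the series, first, only, none or still open, it means among the compounds named here.

Working notes on the series.

Among the measured compounds shown here, compound 1 `CCC(c1ccccc1)c1nc2c(C(F)(F)F)cccc2c(C(=O)O)c1O` and compound 2 `O=C(O)c1c(O)c(C2(c3cccs3)CC2)nc2c(C(F)(F)F)cccc12` are the two measured members of the shared core. In an assay on isolated protein for inhibition of P-selectin glycoprotein ligand 1 (Homo sapiens), read by surface plasmon resonance, tested at 250 uM (a lower number here means less inhibition, a higher number more inhibition at the concentration tested (going by the name of the read-out)), compound 1 gives 55%, while compound 2 gives 15%, the lowest of the two numbers, with compound 1 as the nearest neighbour. For the measured compounds named here, the single measured step, a number 40 percentage points lower from compound 1 to compound 2 (beyond the scatter), exchanged 1-phenylpropyl for 1-(thiophen-2-yl)cyclopropyl on an aromatic carbon and is large.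

Compound 3 `O=C(O)c1c(O)c(C2(c3ccc(C(F)(F)F)cc3)CC2)nc2c(C(F)(F)F)cccc12` is not yet measured. It differs from compound 2 as follows: 4-(trifluoromethyl)phenyl in place of thiophen-2-yl on a saturated ring carbon. Going by the values given here, only the step from compound 1 to compound 2 bears on this, and only in part: it altered both the aryl group and the saturated link at once. What share of the drop goes with the aryl exchange alone is not shown by the two measured compounds. Moving back to a six-membered carbon ring, now carrying trifluoromethyl, is taken to recover some but not all of the gap to compound 1, and a moderate rise is expected.

Compound 3 is therefore estimated at 28%, in the range 10% to 48%, the expected step being a number 13 percentage points higher from compound 2 to compound 3 (beyond the scatter).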

Compound 3, a percentage reported as inhibition, at one concentration (the size of the read-out at that concentration, not a potency): 47%
Compound 3: middle estimate off by 19 percentage points, on the low side; the measured number falls inside the stated range.
By their numbers in this assay, from the lowest: compound 2; then compounds 3 and 1 (each within the scatter of the next).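

With the three-membered saturated ring held constant, the aryl group on its ring carbon alone accounts for a large change in this assay, a number 32 percentage points higher from compound 2 to compound 3 (beyond the scatter), so this position responds strongly to the aryl exchange even without any change in the saturated link. The low number of compound 2 therefore does not follow from the three-membered ring alone: compound 3, which keeps that ring, gives 47%, and compound 1, with the open 1-phenylpropyl group, gives 55%, two values within the scatter of each other, so the ring and a number at the level of compound 1 are compatible when 4-(trifluoromethyl)phenyl is the aryl group. No measurement at hand offers an explanation for the size of this step.

The compounds shown do not separate the contribution of the six-membered aromatic ring from that of its trifluoromethyl group, a question that a plain phenyl on the same saturated ring carbon would address directly. Also open, as far as these compounds go, is whether a nitrile or a methoxy group in place of the trifluoromethyl would hold the number of compound 3 in this assay.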